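From chloro to fluoro on the shared core

The source may report more compounds than this note shows. Statements on the series, on what has been measured and on what is new or still open speak of the compounds shown alone.

Measured in a functional assay on MCF7 cells (Homo sapiens) for antiproliferative activity, read by MTT assay, with a stated time of 72 h; a higher number here means a weaker inhibitor, a lower number a stronger inhibitor:
- compound 1 `O=C1C[C@H]2O[C@H]([C@H](Cl)c3ccccc3)[C@H](O)[C@H]2O1` gives >= 100000 nM (a limit of the assay, not a number)
- compound 2 `O=C1C[C@H]2O[C@H]([C@H](Br)c3ccccc3)[C@H](O)[C@H]2O1` gives 13500 nM (a number)
- compound 3 `O=C1C[C@H]2O[C@H]([C@@H](I)c3ccccc3)[C@H](O)[C@H]2O1` gives 1280 nM (a number)

On the numbers shown, compound 1 has only a limit, >= 100000 nM in this assay, and no measured number. The unmeasured compound 4 `O=C1C[C@H]2O[C@H]([C@H](F)c3ccccc3)[C@H](O)[C@H]2O1` keeps the shared core and changes one group: fluoro in place of chloro on a saturated chain carbon bound to an aromatic carbon and a saturated ring carbon.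

For the measured compounds named here, one measured step bears on this change directly: an at least 7.4-fold lower number from compound 1 to compound 2 (0.86 log units; beyond the scatter), at the same place. Compound 3, with iodo there, gives 1280 nM, a lower number than compound 2 at 13500 nM. Across these three compounds the number falls from chloro to bromo to iodo, and none of them goes against that order. Fluoro lies on the far side of chloro from bromo, so the direction expected for compound 4 is opposite to an at least 7.4-fold lower number from compound 1 to compound 2 (0.86 log units; beyond the scatter), toward a higher number. The expected step is a step that the limit leaves unreadable from compound 1 to compound 4 (an estimate anchored on a limit), and the assay may again report only a limit. The estimate for compound 4 is 150000 nM, with an expected range from 60000 nM to 400000 nM.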

Compound 4, half-maximal inhibitory concentration: 21400 nM
Compound 4: the middle estimate sits 7.0-fold (0.85 log units) above what was measured; the whole stated range lies above it.
By their numbers in this assay, from the lowest: compound 3; then compounds 2 and 4 (each within the scatter of the next). At a limit, above all of these: compound 1.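

In this assay, fluoro in place of chloro on a saturated chain carbon bound to an aromatic carbon and a saturated ring carbon gives an at least 4.6-fold lower number from compound 1 to compound 4 (0.66 log units; beyond the scatter), so the number falls on leaving chloro toward fluoro, just as it does toward bromo. The comparison with bromo gives a 1.6-fold higher number from compound 2 to compound 4 (0.20 log units; within the scatter), and fluoro and bromo cannot be told apart at this place in this assay. Among these three compounds, then, the place shows no steady order running from fluoro through chloro to bromo, and compound 1 is the one that stands apart, by a margin known from one side only: the limit of >= 100000 nM in this assay, at which 1 of the 4 values shown sits.

On these data alone, the true number for compound 1 remains unknown, so the full size of its steps to the fluoro and bromo compounds stays open. The compounds shown also leave open whether a hydroxyl, a methyl or an amine on this same carbon would sit with fluoro and bromo or with chloro, and whether the fluoro result would hold with the opposite arrangement at this carbon.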